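The compounds below may be only part of what the source reports. "The series", "measured", "known", "first", "only" and "open" are said of these compounds alone.

Measured so far in an assay on HEK293 cells for inhibition of Voltage-dependent T-type calcium channel subunit alpha-1G (Homo sapiens), read by fluorescence, tested at 10 uM; on this read-out lower numbers stand for less inhibition and higher numbers for more inhibition at the one concentration tested (going by the name of the read-out):
compound 1, `CCCc1nc(-c2ccccc2)c(CNCCN2CCN(c3ccccc3F)CC2)o1` — 46.5%
compound 2, `CCCc1nc(-c2ccccc2)c(CNCCN2CCN(c3ccc(C)cc3)CC2)o1` — 48.1%
compound 3, `CCCc1nc(-c2ccccc2)c(CNCCN2CCN(c3cccc(OC)c3)CC2)o1` — 40.2%

The three values of this assay lie within the usual scatter of one another: a number 1.6 percentage points higher from compound 1 to compound 2 (within the scatter), a number 6.3 percentage points lower from compound 1 to compound 3 (within the scatter) and a number 7.9 percentage points lower from compound 2 to compound 3 (within the scatter). Compound 3 gives the smallest of the three numbers, but its distance to compound 1 and to compound 2 is within the scatter, so no ordering can be read from it.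

Compound 4, `CCCc1nc(-c2ccccc2)c(CNCCN2CCN(c3cccc(F)c3)CC2)o1`, has not yet been measured in this assay. It differs from compound 3 by fluoro in place of methoxy on an aromatic carbon. Among the measured compounds shown here, no measured step exchanges the group on this aromatic ring for fluoro; the steps that bear on it only loosely are the two that replace a different aryl group by 3-methoxyphenyl, and both stayed within the scatter. Varying this aryl substituent has so far not moved the number beyond the scatter, so the same is expected here: compound 4 is estimated at 45% (range 30% to 60%), which is expected to amount to a number 4.8 percentage points higher from compound 3 to compound 4 (within the scatter), a step within the scatter.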

Compound 4, a percentage reported as inhibition, at one concentration (the size of the read-out at that concentration, not a potency): 62.3%
Estimate against measurement, compound 4: 17.3 percentage points below; the whole stated range lies below it.
By their numbers in this assay, from the lowest: compounds 3, 1 and 2 (each within the scatter of the next); then compound 4.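

In this assay, among the compounds shown here, the aryl group on the ring amine nitrogen does move the number: fluoro in place of methoxy gives a number 22.1 percentage points higher from compound 3 to compound 4 (beyond the scatter), the first change beyond the scatter, and 3-fluorophenyl also stands clear of 4-methylphenyl, with a number 14.2 percentage points higher from compound 2 to compound 4 (beyond the scatter). Where the fluoro sits counts as well, since 3-fluorophenyl in place of 2-fluorophenyl gives a number 15.8 percentage points higher from compound 1 to compound 4 (beyond the scatter). Nothing measured here accounts for these steps. Open, on these data alone, is whether chloro or nitrile in place of this fluoro holds the number, and how 4-fluorophenyl compares.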